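This account rests on a few compounds, and the source may have more. Where it says the series, first, only, none or still open, it means among the compounds named here.

Measured compounds in a functional assay on HepG2 cells (Homo sapiens) for antiproliferative activity, read by XTT assay, with a stated time of 72 h; a lower number here means a stronger inhibitor, a higher number a weaker inhibitor:
- compound 1 `O=c1[nH]cnc2c1c(-c1ccoc1)cn2[C@@H]1O[C@H](CO)[C@@H](O)[C@H]1O`: 12100 nM
- compound 2 `O=c1[nH]cnc2c1c(-c1cccs1)cn2[C@@H]1O[C@H](CO)[C@@H](O)[C@H]1O`: > 20000 nM
- compound 3 `Nc1nc2c(c(-c3cccs3)cn2[C@@H]2O[C@H](CO)[C@@H](O)[C@H]2O)c(=O)[nH]1`: > 20000 nM

The value given for compound 2 is a limit of the assay, not a number. The value given for compound 3 is likewise a limit. Two of the three values therefore sit at the limit of > 20000 nM in this assay, at which 2 of the 3 values shown sit, which leaves the series thinly read.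

The change from compound 2 to compound 1 is furan-3-yl in place of thiophen-2-yl on an aromatic carbon. It produced an at least 1.6-fold lower number from compound 2 to compound 1 (0.21 log units; that floor lies within the scatter). The two cores differ by amino in place of hydrogen on an aromatic carbon; that step, a step that the two limits leave unreadable from compound 2 to compound 3, cannot be sized because both ends are limits.

Compound 4 `Nc1nc2c(c(-c3ccoc3)cn2[C@@H]2O[C@H](CO)[C@@H](O)[C@H]2O)c(=O)[nH]1` is not yet measured. It carries furan-3-yl in place of thiophen-2-yl on an aromatic carbon; the place line reads word for word as for the change from compound 2 to compound 1, so this is the same change on the core of compound 3. The expected step is an at least 1.3-fold lower number from compound 3 to compound 4 (0.12 log units; that floor lies within the scatter), resting on the measured step of an at least 1.6-fold lower number from compound 2 to compound 1 (0.21 log units; that floor lies within the scatter), whose floor lies within the scatter. Because compound 3 stands at a limit, a limit is again a real possibility for compound 4.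

Compound 4 is estimated at 15000 nM, expected between 6000 nM and 40000 nM.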

Compound 4, half-maximal inhibitory concentration: > 20000 nM
Compound 4 was reported as a limit (the forecaster's own chance of this, stated with the estimate: 50%); middle value at least 1.3-fold (0.12 log units) away from the limit.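

In this assay compound 4 gives > 20000 nM, which is a limit of the assay and not a number. The step for furan-3-yl in place of thiophen-2-yl on the core of compound 3 cannot be read, like every other step with a limit at both ends, and the data show neither that this change carries over from the core of compound 1 nor that it fails to. The one readable new step, for amino in place of hydrogen on an aromatic carbon, is an at least 1.6-fold higher number from compound 1 to compound 4 (0.21 log units; that floor lies within the scatter), and most of the series rests at a single value: the limit of > 20000 nM in this assay, at which 3 of the 4 values shown sit.

The compounds shown leave open how the core of compound 3 responds to any group that would bring its value to a number rather than a limit. A phenyl ring, a primary amine or a longer alkyl chain on that aromatic carbon would show whether compound 1 remains the only one of these compounds with a number.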